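This account rests on a few compounds, and the source may have more. Where it says the series, first, only, none or still open, it means among the compounds named here.

Compound 1 `CCC(C)n1ncn(-c2ccc(N3CCN(c4ccc(OC[C@@H]5CO[C@@](Cn6ccnc6C)(c6ccc(Cl)cc6Cl)O5)cc4)CC3)cc2)c1=O` gives 173 nM
Compound 2 `CCC(C)n1ncn(-c2ccc(N3CCN(c4ccc(OC[C@@H]5CO[C@@](Cn6cnc(C)c6)(c6ccc(Cl)cc6Cl)O5)cc4)CC3)cc2)c1=O` gives 102 nM

Both numbers come from a functional assay on HUVEC cells (Homo sapiens), read by scintillation counting and thymidine incorporation, with a stated time of 24 h; a lower number here means a stronger inhibitor, a higher number a weaker inhibitor. Among the measured compounds shown here, compound 2 stands within the scatter of compound 1, the only other measured compound, so the two cannot be told apart. Compound 3 `CCC(C)n1ncn(-c2ccc(N3CCN(c4ccc(OC[C@@H]5CO[C@@](Cn6cc(C)nc6C)(c6ccc(Cl)cc6Cl)O5)cc4)CC3)cc2)c1=O` is the next compound to consider, and its difference from compound 2 is methyl in place of hydrogen on an aromatic carbon. This is methyl in place of hydrogen on an aromatic carbon, between two ring nitrogen atoms, and it turns 4-methyl-1H-imidazol-1-yl into 2,4-dimethyl-1H-imidazol-1-yl. The new group thus holds both methyl groups that compound 1 and compound 2 carry singly. For the measured compounds named here, the one measured step that bears on this is a 1.7-fold lower number from compound 1 to compound 2 (0.23 log units; within the scatter), the exchange of 2-methyl-1H-imidazol-1-yl for 4-methyl-1H-imidazol-1-yl. Going by the values given here, that step stayed small, but no measured compound yet carries both methyl groups, so the evidence is thin. No change beyond the scatter is therefore expected in this assay. The estimated step is a 1.3-fold higher number from compound 2 to compound 3 (0.11 log units; within the scatter). Compound 3 is expected at about 130 nM, with an estimated range from 60 nM to 280 nM.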

Compound 3, half-maximal inhibitory concentration: 492 nM
Estimate against measurement, compound 3: 3.8-fold (0.58 log units) below; measured number above the stated range.
By their numbers in this assay, from the lowest: compounds 2 and 1 (each within the scatter of the next); then compound 3.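

In this assay, two methyl groups that could not be told apart when carried singly behave differently when carried together: placing a methyl on the aromatic carbon between two ring nitrogen atoms gives a 4.8-fold higher number from compound 2 to compound 3 (0.68 log units; beyond the scatter), and the route from the other single-methyl compound gives a 2.8-fold higher number from compound 1 to compound 3 (0.45 log units; beyond the scatter). Compound 1 already carries a methyl at that carbon without standing apart from compound 2, so a methyl there is not enough on its own to raise the number, and the effect of this change depends on what else the ring carries, at least among these three compounds. Nothing measured here explains why the second methyl matters, and no independent evidence bears on the result.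

The three compounds cannot show whether the rise comes from this particular pair of methyl groups or would follow from any second group on the ring, such as an ethyl or a chlorine in place of one methyl. They also leave open where the plain 1H-imidazol-1-yl group, with no methyl at all, would stand relative to the single-methyl compounds.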